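The compounds below may be only part of what the source reports. "The series", "measured", "known", "first", "only" and "open" are said of these compounds alone.

Values measured in an in vitro ADME assay on microsomes from liver (Mus musculus) for pharmacokinetics, read by LC-MS, with a stated time of 10 min, tested at 1 uM (on this read-out lower numbers stand for slow clearance and higher numbers for fast clearance), for the three compounds so far:

- compound 1 (`CN1C[C@H](C(=O)Nc2ccc(F)cc2)[C@@H](c2ccc(/C=C/C(=O)Nc3ccccc3N)cc2)C1`) gives 34 mL/min/kg
- compound 2 (`Cc1ccc(NC(=O)[C@H]2CN(C)C[C@@H]2c2ccc(/C=C/C(=O)Nc3ccccc3N)cc2)cc1`) gives 62 mL/min/kg
- compound 3 (`COc1ccc(NC(=O)[C@H]2CN(C)C[C@@H]2c2ccc(/C=C/C(=O)Nc3ccccc3N)cc2)cc1`) gives 54 mL/min/kg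

Among these three numbers compound 3 (54 mL/min/kg) stands second highest, with compound 2 nearest and compound 1 furthest, and its steps to both lie within the scatter.

Compound 4 (`CN1C[C@H](C(=O)Nc2ccc(C#N)cc2)[C@@H](c2ccc(/C=C/C(=O)Nc3ccccc3N)cc2)C1`) is not yet measured. It differs from compound 3 by cyano in place of methoxy on an aromatic carbon, para to a large group (cyano in place of methoxy on an aromatic carbon).

Within the data shown here, three measured steps bear on this change, all at that same carbon. They are methoxy in place of fluoro (a 1.6-fold higher number from compound 1 to compound 3 (0.20 log units; within the scatter)), methoxy in place of methyl (a 1.1-fold lower number from compound 2 to compound 3 (0.06 log units; within the scatter)) and methyl in place of fluoro (a 1.8-fold higher number from compound 1 to compound 2 (0.26 log units; within the scatter)). All three stay within the scatter. None of them involves cyano, so the data hold no direct reading of this group and the range has to stay wide.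

In this assay no change beyond the scatter is expected, an expectation that rests on compound 3 (54 mL/min/kg) and on those small steps. The estimated step is small (a 1.2-fold lower number from compound 3 to compound 4 (0.08 log units; within the scatter)) and stays within the scatter.

For compound 4 the estimated clearance is 45 mL/min/kg with an expected range from 25 mL/min/kg to 80 mL/min/kg in this read-out.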

Compound 4, clearance: 35 mL/min/kg
Estimate against measurement, compound 4: 1.3-fold (0.11 log units) above; low and high end bracket the measured number.
By their numbers in this assay, from the lowest: compounds 1, 4, 3 and 2 (each within the scatter of the next).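

In this assay, among these compounds, this is the first reading of cyano on this aromatic carbon, para to a large group, and the exchanges for methoxy (a 1.5-fold lower number from compound 3 to compound 4 (0.19 log units; within the scatter)) and for methyl (a 1.8-fold lower number from compound 2 to compound 4 (0.25 log units; within the scatter)) both stay within the scatter, so cyano cannot be told apart from either group here. Cyano in place of fluoro (a 1.0-fold higher number from compound 1 to compound 4 (0.01 log units; within the scatter)) gives almost no step at all, and all four groups now seen on this carbon (fluoro, methyl, methoxy and cyano) are joined by steps that lie within the scatter, so among these compounds the position has shown no step that stands clear of repeat measurement. No measurement shown here gives a reason for these numbers.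

Going by these compounds, whether a group of another kind on the same carbon, such as an amine, a carboxylic acid or a trifluoromethyl, would give a step beyond the scatter in this assay remains open. Also open, on these data alone, is whether this tie among the four groups would persist if the shared core were changed elsewhere, or in liver microsomes from another species.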